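The source may report more compounds than this note shows. Statements on the series, on what has been measured and on what is new or still open speak of the compounds shown alone.

Compound 1 `C[C@@H](O[C@H]1CN2C(=O)C=C(c3ccc(CO)cc3)CC2[C@@H]1c1ccc(F)cc1)c1cc(C(F)(F)F)cc(C(F)(F)F)c1`: 0.39 nM
Compound 2 `Cc1cc(C2=CC(=O)N3C[C@H](O[C@H](C)c4cc(C(F)(F)F)cc(C(F)(F)F)c4)[C@@H](c4ccc(F)cc4)C3C2)ccn1`: 0.51 nM

In an assay on CHO cells for displacement of a labelled ligand from Substance-P receptor (Homo sapiens) (a lower number here means a stronger inhibitor, a higher number a weaker inhibitor), compound 1 gives 0.39 nM, and in this assay compound 2 gives 0.51 nM. Going by the values given here, compound 2 thus stands at one end of this pair of two numbers, but the only step that separates it from compound 1, a 1.3-fold higher number from compound 1 to compound 2 (0.12 log units; within the scatter), lies within the scatter, so the two compounds cannot be told apart on these data.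

Compound 3 `C[C@@H](O[C@H]1CN2C(=O)C=C(c3cnn(C)c3)CC2[C@@H]1c1ccc(F)cc1)c1cc(C(F)(F)F)cc(C(F)(F)F)c1` differs from compound 2 in one place: 1-methyl-1H-pyrazol-4-yl in place of 2-methylpyridin-4-yl on a double-bonded ring carbon. Among the compounds with values here, the single measured step that bears on this position is a 1.3-fold higher number from compound 1 to compound 2 (0.12 log units; within the scatter), in which one aromatic group was exchanged for another on the same double-bonded ring carbon without moving the number beyond the scatter. Within the data shown here, with no further steps to draw on, the expectation for compound 3 is that this second exchange at the same position will likewise produce no step beyond the scatter, a 1.4-fold higher number from compound 2 to compound 3 (0.14 log units; within the scatter). Compound 3 is therefore estimated to give 0.7 nM in this assay, with a range from 0.25 nM to 2 nM.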

Compound 3, half-maximal inhibitory concentration: 0.13 nM
For compound 3 the middle estimate is 5.4-fold (0.73 log units) above the measured one, and the stated range ends above it.
By their numbers in this assay, from the lowest: compound 3; then compounds 1 and 2 (each within the scatter of the next).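

Going by these compounds alone, the position on the double-bonded ring carbon proves sensitive to the group it carries: in this assay, 1-methyl-1H-pyrazol-4-yl in place of 2-methylpyridin-4-yl gives a 3.9-fold lower number from compound 2 to compound 3 (0.59 log units; beyond the scatter), the first step at this position to lie beyond the scatter, though it is modest in size. The same group in place of 4-(hydroxymethyl)phenyl gives a 3.0-fold lower number from compound 1 to compound 3 (0.48 log units; beyond the scatter), also modest and beyond the scatter. Compound 3 therefore has the lowest number of the three, while compound 1 and compound 2, each with a six-membered aromatic ring at this carbon, remain within the scatter of each other.

With a single five-membered ring at this position, the compounds shown do not separate the effect of ring size from that of the second ring nitrogen or the methyl on the ring, and they leave open how an unsubstituted 1H-pyrazol-4-yl, a thiazol-5-yl or an aminomethyl group would behave here. Nothing available accounts for either step.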